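A few compounds are considered here, and "the series" means these few. Any claim that something is new, unique, unknown or untested is made for them only; others in the source may bear on it.

Of the compounds shown here, two of a shared core have been measured in a functional assay on HeLa cells (Homo sapiens) for cytotoxicity, read by MTT assay, with a stated time of 72 h; a higher number here means a weaker inhibitor, a lower number a stronger inhibitor. Compound 1 `Cc1cccc(CSc2cc(Cl)c(C)cc2S(=O)(=O)/N=C(\N)n2nccc2-c2ccccc2)c1` gives 8000 nM in this assay, the lower of the two numbers. For the measured compounds named here, compound 2 `Cc1cc(-c2ccccc2)n(/C(N)=N/S(=O)(=O)c2cc(C)c(Cl)cc2SCc2cccc(C(F)(F)F)c2)n1` gives 98000 nM in this assay, a clearly higher number, and the gap between the two lies beyond the usual scatter; since compound 2 differs from compound 1 in more than one place, these two values alone show only that compound 1 is the stronger of the pair.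

Compound 3 `Cc1cc(S(=O)(=O)/N=C(\N)n2nccc2-c2ccccc2)c(SCc2ccccc2C(F)(F)F)cc1Cl` has not yet been measured in this assay. It differs from compound 1 in a single place: 2-(trifluoromethyl)phenyl in place of 3-methylphenyl on a saturated chain carbon bound to a sulfur. The change keeps the same count of hydrogen-bond donors and acceptors and the same absence of charge, and only the ring's substituent and its position on the ring change.

Going by the values given here, no measured pair in this set isolates this exact change. The step from compound 1 to compound 3 is expected to be a modest rise, a 1.9-fold higher number from compound 1 to compound 3 (0.27 log units; within the scatter), and may fall within the scatter. Compound 3 is therefore estimated to give about 15000 nM in this assay, with a plausible range from 5000 nM to 50000 nM.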

Compound 3, half-maximal inhibitory concentration: 20000 nM
Compound 3: the middle estimate sits 1.3-fold (0.12 log units) below what was measured; low and high end bracket the measured number.
By their numbers in this assay, from the lowest: compound 1; then compound 3; then compound 2.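

In this assay, placing 2-(trifluoromethyl)phenyl where compound 1 carries 3-methylphenyl, on a saturated chain carbon bound to a sulfur, gives a 2.5-fold higher number from compound 1 to compound 3 (0.40 log units; beyond the scatter). For the compounds shown here, this is the first comparison in the set that changes only one place, so it shows that this group alone can shift the read-out, with a modest loss of strength in this cell assay. Both the substituent and its position on the ring change in this single step, and no supporting data on hand explain the shift.

The compounds shown leave open whether the substituent or its position on the ring accounts for the step, a question that a comparison of 2-methylphenyl with 3-methylphenyl on the core of compound 1 could help to separate. They also leave open how an amine or a carboxylic acid on this ring, or a longer chain in place of the benzyl group, would read in this assay.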